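Chlorinated phenylethyl ureas: whole-organism response in rice

The source may report more compounds than this note shows. Statements on the series, on what has been measured and on what is new or still open speak of the compounds shown alone.

Measured so far:
- Compound 1, `C[C@H](NC(=O)Nc1ccccc1Cl)c1ccccc1`: in an ADME assay on the whole organism with Oryza sativa as the target, tested at 0.1 uM (a higher number here means a weaker effect of the compound at the concentration tested, a lower number a stronger effect), compound 1 gives 99%
- Compound 2, `C[C@H](NC(=O)Nc1cccc(Cl)c1)c1ccccc1`: in this assay compound 2 gives 103%
- Compound 3, `C[C@@H](NC(=O)Nc1cccc(Cl)c1Cl)c1ccccc1`: in this assay compound 3 gives 100%

All three measured compounds share the same core and differ only in the number and placement of chlorine on the aryl ring of the urea, and in the drawn configuration of the chain carbon. On the numbers shown, compound 3 lies alongside compound 1 and compound 2; compound 1 is its nearest neighbour and compound 2 its furthest, yet both gaps fall within the scatter of repeated measurements, so no ordering among the three can be read from these values.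

Compound 4, `C[C@H](NC(=O)Nc1cccc(Cl)c1Cl)c1ccccc1`, is the next compound to be measured in this assay. Relative to compound 3 the change is the two compounds have the same atoms and bonds and differ only in configuration as drawn: 1 of 1 stereo elements differ; a stereocentre at a saturated chain carbon is drawn R in compound 3 and S in compound 4. For the measured compounds named here, no step between two measured compounds is available from which to judge what such a change does in this read-out. Given that compound 1, compound 2 and compound 3 sit within the scatter of one another regardless of substitution and drawn configuration, no step beyond the scatter is expected in either direction. The step of no change at the digits printed from compound 3 to compound 4 (within the scatter) is therefore expected to be negligible. For compound 4 the expected value in this assay is 100%, with a range from 90% to 108%.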

Compound 4, a percentage reported as activity, at one concentration (the size of the read-out at that concentration, not a potency): 100%
For compound 4 middle estimate and measured number coincide at the digits printed, and the stated range covers the measured number.
By their numbers in this assay, from the lowest: compounds 1, 3, 4 and 2 (each within the scatter of the next).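

Reversing the drawn configuration at the saturated chain carbon now has a measured step of its own in this assay: no change at the digits printed from compound 3 to compound 4 (within the scatter), so at this position the change from R to S gives no separation beyond the scatter. Chloro in place of hydrogen on an aromatic carbon also gains its first measured steps, a number 3 percentage points lower from compound 2 to compound 4 (within the scatter) and a number 1 percentage points higher from compound 1 to compound 4 (within the scatter), and both of these remain within the scatter, so a second chlorine on the aryl ring shows no separable effect in this pair of comparisons. The first step can be read as a comparison of configuration alone on one basis: the fact that compounds 3 and 4 differ only in the configuration as drawn.

As far as these compounds go, all of these readings come from a single concentration, so it remains open whether configuration or the added chloro would separate the compounds at any other concentration. From the compounds shown here alone, it also remains open whether a carboxylic acid or an amine on the aryl ring, or a longer chain in place of the methyl on the chain carbon, would give a step beyond the scatter in this assay.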